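From Pyridine Back to a Dimethylated Benzene Amide

The compounds below may be only part of what the source reports. "The series", "measured", "known", "first", "only" and "open" are said of these compounds alone.

Within the data shown here, compound 2 `O=C(NCN1CCC(c2cccc[n+]2[O-])CC1)c1ccccn1` gives the highest of the two numbers so far in a functional assay on HEK293 cells for agonist activity at D(4) dopamine receptor (Homo sapiens), read by FLIPR (on this read-out lower numbers stand for an effect already at smaller amounts and higher numbers for an effect only at larger amounts of compound), at 3150 nM. Among the measured compounds shown here, its nearest neighbour is compound 1 `O=C(NCN1CCC(c2cccc[n+]2[O-])CC1)c1ccccc1`, which in this assay gives 532 nM; the step of a 5.9-fold higher number from compound 1 to compound 2 (0.77 log units; beyond the scatter) is the only measured change that bears here. Compound 3 `Cc1ccc(C(=O)NCN2CCC(c3cccc[n+]3[O-])CC2)cc1C` has not yet been measured. Its change from compound 2 is 3,4-dimethylphenyl in place of pyridin-2-yl on a carbonyl carbon. This undoes the exchange seen in that measured step and adds two methyl groups onto the carbon-only ring, so the step is expected to run back in the opposite direction and to be of at least the size observed, not within the scatter. Compound 3 is therefore estimated to give 350 nM in this assay, with a range from 100 nM to 1200 nM, meaning an expected step of a 9.0-fold lower number from compound 2 to compound 3 (0.95 log units; beyond the scatter).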

Compound 3, half-maximal effective concentration: 38 nM
Beside the measured number, compound 3's estimate is 9.2-fold (0.96 log units) above it; the whole stated range lies above it.
By their numbers in this assay, from the lowest: compound 3; then compound 1; then compound 2.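

In this assay, the group on the carbonyl carbon proves able to move the number much further than the first exchange suggested: 3,4-dimethylphenyl in place of pyridin-2-yl gives an 83-fold lower number from compound 2 to compound 3 (1.92 log units; beyond the scatter) and marks this position as highly responsive to the change. The same group in place of phenyl gives a 14-fold lower number from compound 1 to compound 3 (1.15 log units; beyond the scatter) and so shows that the two methyl groups on the carbon-only ring go with a drop of their own, which the comparison of compound 1 with compound 2 could not show. Nothing available gives a reason for either step.

On these data alone, it remains open whether a single methyl group on the phenyl ring would carry the same step, or whether chloro, methoxy or ethyl groups would serve in place of the methyl groups. Also open, as far as these compounds go, is what the two methyl groups would do on a pyridin-2-yl ring.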